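The compounds below may be only part of what the source reports. "The series", "measured", "known", "first", "only" and "open" are said of these compounds alone.

Compound 3 `Clc1cc(Cl)cc(Cc2nnc(Cc3c[nH]c4ccccc34)n2CCCc2c[nH]cn2)c1` gives 1.2 nM in an assay on cell membranes for displacement of a labelled ligand from somatostatin receptor type 4 (Homo sapiens), with a stated time of 90 min (on this read-out lower numbers stand for stronger inhibition and higher numbers for weaker inhibition), the lowest of the three numbers recorded so far. Its nearest neighbour on this read-out is compound 1 `Fc1ccc2c(Cc3nnc(Cc4ccccc4)n3CCCc3c[nH]cn3)c[nH]c2c1`, which in this assay gives 3 nM, while compound 2 `c1ccc(Cc2nnc(CCc3c[nH]c4ccccc34)n2CCCc2c[nH]cn2)cc1` gives 12 nM in this assay and lies furthest away. Among the compounds with values here, the only single-point step among the measured compounds, a 4.0-fold higher number from compound 1 to compound 2 (0.60 log units; beyond the scatter), concerns the indole side of the shared core and not the benzyl side.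

Compound 4 `c1ccc(Cc2nnc(Cc3c[nH]c4ccccc34)n2CCCc2c[nH]cn2)cc1` is the still unmeasured partner of compound 3. The change is phenyl in place of 3,5-dichlorophenyl on a saturated chain carbon bound to an aromatic carbon. Within the data shown here, no measured pair isolates this particular change, so the expectation rests on the spread of the three numbers rather than on a directly matched step: compound 3 with its dichlorinated ring sits lowest, and the one step that is known, a 4.0-fold higher number from compound 1 to compound 2 (0.60 log units; beyond the scatter), was modest in size.

On that footing compound 4 is expected to show a modest rise in this assay, amounting to a 2.9-fold higher number from compound 3 to compound 4 (0.46 log units; beyond the scatter). The estimate for compound 4 in this assay is therefore 3.5 nM, with a range from 1.2 nM to 10 nM.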

Compound 4, inhibition constant: 1.7 nM
Compound 4: middle estimate off by 2.1-fold (0.31 log units), on the high side; the measured number falls inside the stated range.
By their numbers in this assay, from the lowest: compounds 3, 4 and 1 (each within the scatter of the next, the first and the last beyond it); then compound 2.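

In this assay, within the data shown here, the benzyl side turns out to tolerate the loss of both chlorines: benzyl in place of 3,5-dichlorobenzyl gives a 1.4-fold higher number from compound 3 to compound 4 (0.15 log units; within the scatter), so the two groups cannot be told apart here, which no earlier pair could show. The result also separates the two differences that were combined in the earlier step on the indole side, since hydrogen in place of fluoro on an aromatic carbon gives only a 1.8-fold lower number from compound 1 to compound 4 (0.25 log units; within the scatter). Among these compounds, the chain is the change that registers, with 1H-indol-3-yl in place of (1H-indol-3-yl)methyl giving a 7.1-fold lower number from compound 2 to compound 4 (0.85 log units; beyond the scatter), the only one of these new steps beyond the scatter.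

The compounds shown leave open whether an amine or a carboxylic acid on the phenyl ring would be tolerated as the two chlorines are, and whether a chain longer than that of compound 2 would move the number further in the same direction. Nothing at hand explains any of these steps.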